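Coumarin amide series: adenosine A2b binding at one concentration

The source may report more compounds than this note shows. Statements on the series, on what has been measured and on what is new or still open speak of the compounds shown alone.

Measured so far:
- compound 1, `COc1cccc2cc(C(=O)NCC(=O)O)c(=O)oc12`, gives 35%
- compound 2, `O=C(NC1CCCC1)c1cc2ccccc2oc1=O`, gives 18%
- compound 3, `N=c1oc2ccc(Br)cc2cc1C(=O)NCCO`, gives 15%

All three numbers come from an assay on HEK293 cells for displacement of a labelled ligand from adenosine receptor A2b (Homo sapiens), read by scintillation counting, with a stated time of 30 min, tested at 10 uM; on this read-out lower numbers stand for less inhibition and higher numbers for more inhibition at the one concentration tested (going by the name of the read-out). Compound 1 stands highest of the three; the nearest, compound 2, sits a gap lower that is beyond the scatter, and compound 3 sits further below, also beyond the scatter. Among the measured compounds shown here, no two measured compounds differ in one place only, so no single-change step is available from the data.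

Compound 4, `COCCNC(=O)c1cc2cccc(OC)c2oc1=O`, is not yet measured. Set against compound 1 it differs by methoxymethyl in place of carboxy on a saturated chain carbon bound to an amide-type nitrogen. For the measured compounds named here, no measured pair shows what this exchange does, so the expected size of the step cannot be read from the series. The working expectation is a modest downward step in this assay, a number 10 percentage points lower from compound 1 to compound 4 (within the scatter), estimated with a wide range, since compounds 2 and 3 with other amide substituents sit lower than compound 1. For compound 4 the estimate in this assay is 25%, expected between 5% and 45%.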

Compound 4, a percentage reported as inhibition, at one concentration (the size of the read-out at that concentration, not a potency): 18%
Compound 4: middle estimate off by 7 percentage points, on the high side, and the stated range covers the measured number.
By their numbers in this assay, from the lowest: compounds 3, 2 and 4 (each within the scatter of the next); then compound 1.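

In this assay, among the compounds shown here, methoxymethyl in place of carboxy on a saturated chain carbon bound to an amide-type nitrogen gives a number 17 percentage points lower from compound 1 to compound 4 (beyond the scatter), the only single-place step so far, and it shows that the number responds to the group carried at this place on the core of compound 1. The exchange keeps the count at 3 heavy atoms and 1 hydrogen-bond acceptor, while the hydrogen-bond donor count goes from 1 to 0 and the double bond outside aromatic rings is lost. Nothing measured bears on why the number moves.

As far as these compounds go, whether a methyl ester, a primary carboxamide, an amine or a longer chain ending in carboxy at this place would hold the number of compound 1 remains open. Steps to compounds 2 and 3 cannot be read, as each differs from compound 1 and compound 4 in more than one place.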